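The source may hold more compounds than are shown below. What is called first, only, known or untested is meant among the compounds shown, and "the series" means these compounds.

Of the compounds shown here, two have so far been tested in a functional assay on SK-BR-3 cells (Homo sapiens) for antiproliferative activity, read by MTT assay, with a stated time of 72 h; on this read-out higher numbers stand for weaker inhibition and lower numbers for stronger inhibition. Compound 1 `CNc1cc(C)c2cc(NC(=O)c3ccc(Cl)c(Cl)c3)ccc2n1` gives 6350 nM in this assay, while compound 2 `CCc1ccccc1C(=O)Nc1ccc2nc(N3CCN(CC)CC3)cc(C)c2c1` gives 23900 nM in this assay, the higher of the two numbers by a margin beyond the usual scatter. Compound 3 `CCN1CCN(c2cc(C)c3cc(NC(=O)c4ccco4)ccc3n2)CC1` is not yet measured; it differs from compound 2 in one place, (furan-2-yl in place of 2-ethylphenyl on a carbonyl carbon). Within the data shown here, no measured pair shows this particular change, so its direction is open. Compound 3 is expected to give about 15000 nM in this assay, within 5000 nM to 50000 nM. The expected step of a 1.6-fold lower number from compound 2 to compound 3 (0.20 log units; within the scatter) is small, at most modestly beyond the scatter.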

Compound 3, half-maximal inhibitory concentration: 37500 nM
Estimate against measurement, compound 3: 2.5-fold (0.40 log units) below; the range from low to high includes it.
By their numbers in this assay, from the lowest: compound 1; then compounds 2 and 3 (each within the scatter of the next).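

Putting furan-2-yl in place of 2-ethylphenyl on a carbonyl carbon gives a 1.6-fold higher number from compound 2 to compound 3 (0.20 log units; within the scatter) in this assay. At this position, then, a five-membered aromatic ring holding one oxygen and a six-membered aromatic ring of carbon only, carrying its ethyl group, cannot be told apart on this read-out. No measurement shown here explains this result. On these data alone, whether an aromatic ring carrying an amine or a carboxylic acid on this same carbonyl carbon would move the number beyond the scatter remains open.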